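Cyclohexyl for Cyclopropyl on the Shared Core

This account rests on a few compounds, and the source may have more. Where it says the series, first, only, none or still open, it means among the compounds named here.

For the measured compounds named here, compound 2 `[O-][n+]1nc(NC2CC2)[n+]([O-])c2ccccc21` gives 15900 nM in a functional assay on PC-3 cells (Homo sapiens) for cytotoxicity, read by MTT assay, with a stated time of 48 h; a higher number here means a weaker inhibitor, a lower number a stronger inhibitor; it stands beside the only other measured compound, compound 1 `[O-][n+]1nc(NCCO)[n+]([O-])c2ccccc21`, which gives 22400 nM, and the two lie within the scatter of each other. Going by the values given here, the single measured step, a 1.4-fold lower number from compound 1 to compound 2 (0.15 log units; within the scatter), is within the scatter. Compound 3 `[O-][n+]1nc(NC2CCCCC2)[n+]([O-])c2ccccc21` differs from compound 2 by cyclohexyl in place of cyclopropyl on a nitrogen on an aromatic ring. Among the compounds with values here, no measured step covers this exchange, and the one step known was small, so compound 3 is expected to change little, a 1.2-fold lower number from compound 2 to compound 3 (0.09 log units; within the scatter). The estimate for compound 3 is 13000 nM, in a range from 5000 nM to 32000 nM.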

Compound 3, half-maximal inhibitory concentration: 10500 nM
Compound 3: the middle estimate sits 1.2-fold (0.09 log units) above what was measured; the range from low to high includes it.
By their numbers in this assay, from the lowest: compounds 3, 2 and 1 (each within the scatter of the next, the first and the last beyond it).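

Enlarging the ring on this nitrogen, cyclohexyl in place of cyclopropyl, gives a 1.5-fold lower number from compound 2 to compound 3 (0.18 log units; within the scatter) in this assay and so adds no change that can be told from scatter. Set against the 2-hydroxyethyl group, however, cyclohexyl gives a 2.1-fold lower number from compound 1 to compound 3 (0.33 log units; beyond the scatter) and is the first exchange at this position to pass beyond the scatter, though only modestly. Nothing available explains either step. The compounds shown leave open how a longer open carbon chain or a chain ending in an amine would read at this nitrogen.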